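The source may hold more compounds than are shown below. What is called first, only, known or untested is meant among the compounds shown, and "the series" means these compounds.

Compound 1 `O=C1O[C@H]([C@@H](O)Cn2cc(-c3ccc(Br)cc3)nn2)C(OCc2ccccc2)=C1OCc1ccccc1`: 3910 nM
Compound 2 `COc1ccccc1-c1cn(C/C=C2\OC(=O)C(OCc3ccccc3)=C2OCc2ccccc2)nn1`: > 100000 nM

For the measured compounds named here, compound 1 is the only compound of the pair that yields a number in a functional assay on HeLa cells (Homo sapiens) for antiproliferative activity, read by MTT assay, with a stated time of 72 h; on this read-out lower numbers stand for stronger inhibition and higher numbers for weaker inhibition; in this assay compound 1 gives 3910 nM. Compound 2 is a different case: in this assay compound 2 reaches only a limit of the assay, > 100000 nM, and not a number. Compound 2 thus sits at the limit of > 100000 nM in this assay, at which 1 of the 2 values shown sits. So compound 1 stands alone as the single measured number, and no step between two measured compounds is available to show how a change of the kind below plays out.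

The step of interest leads to compound 3 `Cc1ccc(S(=O)(=O)NCc2cn(C[C@H](O)[C@H]3OC(=O)C(OCc4ccccc4)=C3OCc3ccccc3)nn2)cc1`, which is not yet measured. The change is (((4-methylphenyl)sulfonyl)amino)methyl in place of 4-bromophenyl on an aromatic carbon.

With only compound 1 as a reference, a modest step toward weaker inhibition is expected, estimated as a 2.0-fold higher number from compound 1 to compound 3 (0.31 log units; beyond the scatter). Compound 3 is expected to give 8000 nM, within a range from 2000 nM to 40000 nM.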

Compound 3, half-maximal inhibitory concentration: 14400 nM
Compound 3: the middle estimate sits 1.8-fold (0.26 log units) below what was measured, and the stated range covers the measured number.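

Placing (((4-methylphenyl)sulfonyl)amino)methyl in place of 4-bromophenyl on this aromatic carbon gives the first step that can be read in this assay: a 3.7-fold higher number from compound 1 to compound 3 (0.57 log units; beyond the scatter). The position therefore tolerates a larger, sulfonyl-bearing group with a hydrogen-bond donor, since compound 3 still gives a number, 14400 nM, although inhibition is weaker than with compound 1. Nothing measured here accounts for the size of this step.

The entering group changes its link to the triazole-bearing carbon, its sulfonyl and its aromatic ring together, so the compounds shown leave open which part carries the step. On these data alone, whether a simple aminomethyl group or a carboxylic acid on this same carbon would keep a number in this assay also remains open.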